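This account rests on a few compounds, and the source may have more. Where it says the series, first, only, none or still open, it means among the compounds named here.

Among the compounds with values here, compound 3 `COC(=O)CC/C=C\CC[C@H]1C(=O)C[C@@H](O)[C@@H]1/C=C/C[C@@](C)(O)/C=C/C1CCCC1` sits second highest of the three numbers so far in a functional assay on the whole organism (stomach) with Canis familiaris (Canis lupus familiaris) as the target; on this read-out higher numbers stand for an effect only at larger amounts of compound and lower numbers for an effect already at smaller amounts. In this assay compound 3 gives 0.0003 mg/kg, compound 2 `COC(=O)CC/C=C\CC[C@H]1C(=O)C[C@@H](O)[C@@H]1/C=C/CC(C)(O)CCC1CCC1` gives 0.00009 mg/kg, and compound 1 `COC(=O)CC/C=C\CC[C@H]1C(=O)C[C@@H](O)[C@@H]1/C=C/C[C@@](C)(O)C#CC1=CCCC1` gives 0.0028 mg/kg. Compound 4 `COC(=O)CC/C=C\CC[C@H]1C(=O)C[C@@H](O)[C@@H]1/C=C/C[C@@](C)(O)/C=C/C1CC1` differs from compound 3 in one place: cyclopropyl in place of cyclopentyl on a double-bonded chain carbon bound to a double-bonded chain carbon. Within the data shown here, no measured step changes only the ring while leaving the rest untouched. The nearest comparisons are a 3.3-fold higher number from compound 2 to compound 3 (0.52 log units; beyond the scatter) and a 31-fold lower number from compound 1 to compound 2 (1.49 log units; beyond the scatter), in which a smaller ring arrives together with a change in the chain between the ring and the carbinol carbon, so the contribution of ring size alone cannot be separated from those numbers. The step of a 9.3-fold lower number from compound 1 to compound 3 (0.97 log units; beyond the scatter) keeps the five-membered ring and changes the chain. With the two-cyclopentylethenyl to two-cyclopropylethenyl exchange unsupported by a clean precedent, the expectation for compound 4 in this assay is a step close to the scatter, estimated as a 1.3-fold higher number from compound 3 to compound 4 (0.12 log units; within the scatter). Compound 4 is therefore estimated at 0.0004 mg/kg, with a range from 0.00008 mg/kg to 0.002 mg/kg.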

Compound 4, dose for half-maximal effect: 0.0001 mg/kg
For compound 4 the middle estimate is 4.0-fold (0.60 log units) above the measured one; low and high end bracket the measured number.
By their numbers in this assay, from the lowest: compounds 2 and 4 (each within the scatter of the next); then compound 3; then compound 1.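

Within the data shown here, with the rest of the molecule held constant, cyclopropyl in place of cyclopentyl on a double-bonded chain carbon bound to a double-bonded chain carbon gives a 3.0-fold lower number from compound 3 to compound 4 (0.48 log units; beyond the scatter) in this assay, the first reading of the ring alone, and the smaller ring gives an effect at smaller amounts. The same ring also gives a 28-fold lower number from compound 1 to compound 4 (1.45 log units; beyond the scatter) and, with its different chain, a 1.1-fold higher number from compound 2 to compound 4 (0.05 log units; within the scatter), so two different combinations of ring and chain now read alike. Nothing available gives a reason for the change at this position.

The compounds shown leave open how a cyclohexyl or a phenyl would read at this place. Among these compounds, they also leave open whether cyclobutyl, seen only in compound 2 on a saturated chain, would fit this pattern on the 2-ethenyl chain.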